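A few compounds are considered here, and "the series" means these few. Any claim that something is new, unique, unknown or untested is made for them only; others in the source may bear on it.

In a functional assay on L02 cells (Homo sapiens) for inhibition, read by MTT assay, with a stated time of 48 h (a lower number here means a stronger inhibitor, a higher number a weaker inhibitor), compound 2 (`COc1ccc2c(=O)c(/C=C/C(=O)Nc3cc(C)ccc3C)coc2c1`) gives > 200000 nM as a limit of the assay, not a number. Compound 1 (`COc1ccc(CNC(=O)/C=C/c2coc3cc(O)ccc3c2=O)cc1`) gives > 200000 nM and this too is a limit. Compound 3 (`COc1ccc(NC(=O)/C=C/c2coc3cc(O)ccc3c2=O)cc1`) gives > 200000 nM and this is again a limit. Compound 2 therefore has no measured position within the series, and the whole picture is the limit of > 200000 nM in this assay, at which 3 of the 3 values shown sit, for now.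

Compound 4 (`COc1ccc2c(=O)c(/C=C/C(=O)NCc3ccc(C)cc3)coc2c1`) is the next to be read. Its change from compound 2 is 4-methylbenzyl in place of 2,5-dimethylphenyl on an amide-type nitrogen with 4-methylbenzyl in place of 2,5-dimethylphenyl on an amide-type nitrogen. Within the data shown here, no measured pair isolates this change. With compound 2 at > 200000 nM as a limit, no step beyond the scatter is expected in this assay and no direction can be assigned. The estimated step of a number no higher from compound 2 to compound 4 (the limit leaves the size open) is expected to stay within the usual scatter. For compound 4 the estimate is 200000 nM with an expected range from 100000 nM to 300000 nM and a report as a limit is the likeliest outcome.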

Compound 4, half-maximal inhibitory concentration: > 200000 nM
Compound 4: a limit, no number (the forecaster's own chance of this, stated with the estimate: 80%); the middle value lies on the limit itself.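

Among these compounds, compound 2 and compound 4 both read only as limits in this assay, so no step between them can be read. Both stand at the one limit shared across the series: the limit of > 200000 nM in this assay, at which 4 of the 4 values shown sit.

The compounds shown leave open which change on the amide-type nitrogen, if any, would give a measured number in this assay.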